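A few compounds are considered here, and "the series" means these few. Any claim that something is new, unique, unknown or untested is made for them only; others in the source may bear on it.

Measured so far in a functional assay on PC-3 cells (Homo sapiens) for cytotoxicity, read by sulforhodamine B assay, with a stated time of 48 h; on this read-out lower numbers stand for stronger inhibition and higher numbers for weaker inhibition:
- compound 1, `COc1cc(C2CC(c3ccc(Br)cc3)=NN2C(C)=O)cc(OC)c1OC`, this assay 3450 nM
- compound 2, `CC(=O)N1N=C(c2ccc(Br)cc2)CC1c1cccc(Cl)c1Cl`, this assay 38800 nM
- compound 3, `CC(=O)N1N=C(c2cccc3ccccc23)CC1c1ccccc1[N+](=O)[O-]`, this assay 3540 nM

Compound 1 has the lowest number of the three in this assay. Compound 3 lies within the scatter of it, so no order between these two can be read. Compound 2 stands beyond the scatter, with a clearly higher number than compound 1.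

The next compound is compound 4, `COc1cc(C2CC(c3cccc4ccccc34)=NN2C(C)=O)cc(OC)c1OC`. It differs from compound 1 in one place: naphthalen-1-yl in place of 4-bromophenyl on a carbon with a double bond to nitrogen. Among the measured compounds shown here, no measured pair in the set shows this change alone, so there is no step to lean on. What can be said is that compound 3, which carries naphthalen-1-yl at that position with a different aryl group on the other ring carbon, gives this assay 3540 nM, a number within the scatter of compound 1. The expected step from compound 1 to compound 4 is therefore a 1.1-fold lower number from compound 1 to compound 4 (0.03 log units; within the scatter), not beyond the scatter in either direction. Compound 4 is estimated at this assay 3200 nM, with a range from 1000 nM to 10000 nM.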

Compound 4, half-maximal inhibitory concentration: 1090 nM
Beside the measured number, compound 4's estimate is 2.9-fold (0.47 log units) above it, and the stated range covers the measured number.
By their numbers in this assay, from the lowest: compound 4; then compounds 1 and 3 (each within the scatter of the next); then compound 2.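

In this assay, the carbon with a double bond to nitrogen now has its first single-change reading: naphthalen-1-yl in place of 4-bromophenyl gives a 3.2-fold lower number from compound 1 to compound 4 (0.50 log units; beyond the scatter). The earlier compounds shown here gave no such reading, as none of them differed in this one place alone, whereas here the rest of the molecule stays fixed and the group with two aromatic rings carries the lower number. Nothing available explains this step.

The pair does not separate the second aromatic ring from the loss of bromine, so a plain phenyl or a naphthalen-2-yl at this carbon remains an open comparison. From the compounds shown here alone, it is also open whether the step holds when the trimethoxy-substituted aryl group on the other ring carbon is replaced, for example by a 2-nitrophenyl or a 2,3-dichlorophenyl.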